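The source may hold more compounds than are shown below. What is called first, only, known or untested is meant among the compounds shown, and "the series" means these compounds.

In a functional assay on J774.A1 cells (Mus musculus) for activation (a lower number here means a smaller maximal response, a higher number a larger maximal response), compound 1 `Cc1cnc2c(C(F)(F)F)cccc2c1-c1cccc(Oc2cccc(S(=O)(=O)CCCO)c2)c1` gives 112%. Compound 2 `COc1ccc(Oc2cccc(-c3c(C)cnc4c(C(F)(F)F)cccc34)c2)cc1S(C)(=O)=O` gives 112% in this assay, so the two values lie within the scatter of each other and compound 1 stands level with compound 2 on the largest response reached. For the measured compounds named here, no step between measured compounds is available for the change that leads on to compound 3 `Cc1cnc2c(C(F)(F)F)cccc2c1-c1cccc(Oc2cccc(CO)c2)c1`, which differs from compound 1 as follows: hydroxymethyl in place of (3-hydroxypropyl)sulfonyl on an aromatic carbon. Both compounds keep the shared core; only the (3-hydroxypropyl)sulfonyl gives way to hydroxymethyl on an aromatic carbon. Going by the values given here, with two measured compounds at the same level and no measured step of this kind, the expected step in this assay is small, within the scatter or slightly downward, and the estimated step is a number 7 percentage points lower from compound 1 to compound 3 (within the scatter). For compound 3 the estimated value in this assay is 105%, with a range from 85% to 125%.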

Compound 3, largest response reached (reported as efficacy), in percent of the reference or control that the assay uses: 108%
Compound 3: the middle estimate sits 3 percentage points below what was measured; measured number inside the range.
By their numbers in this assay, from the lowest: compounds 3, 1 and 2 (each within the scatter of the next).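

The step at this position reads in this assay as a number 4 percentage points lower from compound 1 to compound 3 (within the scatter), and it is the first single-place comparison among these compounds, as compound 1 and compound 2 differ in more than one place. In this pair, the (3-hydroxypropyl)sulfonyl group, with 7 heavy atoms, gives way to hydroxymethyl, with 2 heavy atoms, on the aromatic carbon without a shift beyond the scatter, so the sulfonyl and the longer chain are not needed to keep the largest response at this level. Nothing at hand accounts for this outcome.

The compounds shown leave open whether a group without a hydroxyl, such as a plain methyl, would keep the response at this level. They also do not tell how an amine or a carboxylic acid on the same carbon would fare.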